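Adding a second methoxy group where one already ends the signal

This account rests on a few compounds, and the source may have more. Where it says the series, first, only, none or still open, it means among the compounds named here.

Compound 1 `O=c1oc(-c2ccccc2I)nc2ccccc12` gives 16700 nM in an assay on isolated protein for inhibition of complement C1r subcomponent (Homo sapiens); a higher number here means a weaker inhibitor, a lower number a stronger inhibitor.
Compound 2 `COc1ccc2nc(-c3ccccc3I)oc(=O)c2c1` reaches the limit of this assay, > 62500 nM, not a number.
Compound 3 `COc1ccc2c(=O)oc(-c3ccccc3I)nc2c1` also reaches the limit of this assay, > 62500 nM.

Compound 3 therefore stands at the limit of > 62500 nM in this assay, at which 2 of the 3 values shown sit, so only a floor to its number is known. Compound 4 `COc1cc2nc(-c3ccccc3I)oc(=O)c2cc1OC` differs from compound 3 by methoxy in place of hydrogen on an aromatic carbon. Within the data shown here, two measured steps bear on this change: an at least 3.7-fold higher number from compound 1 to compound 2 (0.57 log units; beyond the scatter) and an at least 3.7-fold higher number from compound 1 to compound 3 (0.57 log units; beyond the scatter), each a methoxy in place of hydrogen on an aromatic carbon, and each carried the number beyond the limit. A further change of the same kind is expected to leave the number beyond the limit again, so the expected step that the limit leaves unreadable from compound 3 to compound 4 is flat or upward. Compound 4 is expected to give 120000 nM, between 45000 nM and 400000 nM, most probably reported only as a limit.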

Compound 4, half-maximal inhibitory concentration: > 62500 nM
Compound 4: a limit, no number (the forecaster's own chance of this, stated with the estimate: 85%); the middle value is on the limit's open side.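

In this assay compound 4 gives only a limit, > 62500 nM and no number. Its steps from compound 2 and from compound 3 cannot be read: the limit of > 62500 nM in this assay, at which 3 of the 4 values shown sit. The compounds shown leave open whether the added methoxy of compound 4 changes the true number at all.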